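The source may report more compounds than this note shows. Statements on the series, on what has been measured and on what is new or still open speak of the compounds shown alone.

Of the compounds shown here, two built on a shared core have been measured in an assay on HEK293 cells for inhibition of Voltage-dependent T-type calcium channel subunit alpha-1H (Homo sapiens), read by patch clamp, using a membrane potential dye; a higher number here means a weaker inhibitor, a lower number a stronger inhibitor. Compound 1 `CC(C)N1CC2(CCN(C(=O)Nc3ccc(F)c(F)c3)CC2)C1c1ccc(Cl)cc1` gives 174 nM. Compound 2 `CC[C@H](C)[C@H](NC(=O)N1CCC2(CC1)CN(C)C2c1ccc(Cl)cc1)C(=O)OC` gives 410 nM, the higher of the two numbers, and its gap to compound 1 lies beyond the usual scatter of repeated measurements, so compound 2 is the weaker inhibitor of the pair. Compound 3 `CN1CC2(CCN(C(=O)Nc3cc(F)cc(F)c3)CC2)C1c1ccc(Cl)cc1` has not yet been measured. It differs from compound 2 in one place: 3,5-difluorophenyl in place of 1-(methoxycarbonyl)-2-methylbutyl on an amide-type nitrogen. After this exchange compound 3 comes close to compound 1, which also carries a difluorophenyl on its amide-type nitrogen and gives 174 nM in this assay. Going by the values given here, no measured pair shows this exchange directly, so the expectation rests on that likeness. Compound 3 is expected to move toward a lower number, a step of a 2.1-fold lower number from compound 2 to compound 3 (0.31 log units; beyond the scatter) in this assay. The estimate for compound 3 is 200 nM, with a range from 80 nM to 500 nM.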

Compound 3, half-maximal inhibitory concentration: 214 nM
Compound 3: the middle estimate sits 1.1-fold (0.03 log units) below what was measured, and the stated range covers the measured number.
By their numbers in this assay, from the lowest: compounds 1, 3 and 2 (each within the scatter of the next, the first and the last beyond it).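

In this assay, replacing the open 1-(methoxycarbonyl)-2-methylbutyl chain with the flat aromatic 3,5-difluorophenyl ring gives a 1.9-fold lower number from compound 2 to compound 3 (0.28 log units; within the scatter) on the same amide-type nitrogen. Going by these compounds alone, this is the first direct comparison at this position, and it shows that two very different groups can give values that cannot be told apart, even though the chain brings an ester and 2 defined stereocentres that the ring lacks. Nothing available explains why the two groups read alike.

As far as these compounds go, whether the fluorines count for anything remains open, and a plain phenyl ring in place of 3,5-difluorophenyl would test that. A carboxylic acid in place of the methyl ester, or a cyclohexyl ring in place of the aromatic ring, would probe this position further.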